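The source may hold more compounds than are shown below. What is called first, only, known or untested is meant among the compounds shown, and "the series" means these compounds.

Compound 1 `CC(=O)O[C@@H]1OC(=O)[C@@](C(C)=O)(C2SCCCS2)[C@@H]1C` is tested in a functional assay on MCF7 cells (Homo sapiens) for cytotoxicity, read by MTT assay (on this read-out lower numbers stand for stronger inhibition and higher numbers for weaker inhibition), and here compound 1 gives only a limit, > 50000 nM, so no number is known for it. This limit is the one described in the limit of > 50000 nM in this assay, at which 1 of the 3 values shown sits. Compound 3 `CC(=O)O[C@@H]1OC(=O)[C@@](C)(C(C)=O)[C@@H]1C` also returns only a limit in this assay, > 10000 nM; that is the limit described in the limit of > 10000 nM in this assay, at which 1 of the 3 values shown sits. Within the data shown here, compound 2 `CC(=O)O[C@@H]1OC(=O)[C@](OC(=O)c2ccccc2)(C(C)=O)[C@@H]1C` is the one member of the series with a number in this assay, where compound 2 gives 22000 nM. Taken together, the three values show no member of the series reaching strong inhibition in this assay, and no step between two measured compounds can be stated from them.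

Compound 4 `CC(=O)O[C@@H]1OC(=O)[C@@H](C(C)=O)[C@@H]1C` differs from compound 1 by a hydrogen atom in place of a group of 6 heavy atoms (4 carbon, 2 sulfur; one six-membered non-aromatic ring with 2 hetero atoms), on a saturated ring carbon, in words: a hydrogen atom in place of a group of 6 heavy atoms (4 carbon, 2 sulfur; one six-membered non-aromatic ring with 2 hetero atoms), on a saturated ring carbon. Nothing in the data measures such a change, and two of the three values are limits. The change from compound 1 to compound 4 is therefore expected to be an at least 1.2-fold lower number from compound 1 to compound 4 (0.09 log units; that floor lies within the scatter), that is, nothing clearly beyond the scatter, with the outcome likely again at a limit. In this assay compound 4 is estimated at 40000 nM, with a plausible range from 15000 nM to 100000 nM.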

Compound 4, half-maximal inhibitory concentration: > 50000 nM
Compound 4: a limit, no number; the forecaster's own chance of this, stated with the estimate: 65%; at least 1.2-fold (0.09 log units) between middle value and limit.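

Compound 1 and compound 4 both stop at a limit in this assay, so no step between them can be read: the limit of > 50000 nM in this assay, at which 2 of the 4 values shown sit.

The compounds shown leave open whether a hydrogen atom in place of the six-membered ring group changes inhibition at all.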